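This account rests on a few compounds, and the source may have more. Where it says the series, first, only, none or still open, it means among the compounds named here.

Measured so far:
compound 1 `Cc1cc(N2CC[C@@H](C)[C@@H](N(C)c3ncnc4[nH]ccc34)C2)n2nc(SCC3CC3)nc2n1` gives 27900 nM in a toxicity assay on GES1 cells (Homo sapiens) for inhibition, read by MTT assay, with a stated time of 72 h; a lower number here means a stronger inhibitor, a higher number a weaker inhibitor
compound 2 `Cc1ccc(CSc2nc3nc(C)cc(N4CC[C@@H](C)[C@@H](N(C)c5ncnc6[nH]ccc56)C4)n3n2)cc1` gives 82500 nM in this assay

Compound 1 holds the lowest of these two numbers; its nearest neighbour is compound 2, reached by a 3.0-fold higher number from compound 1 to compound 2 (0.47 log units; beyond the scatter). Compound 3 `Cc1cc(N2CC[C@@H](C)[C@@H](N(C)c3ncnc4[nH]ccc34)C2)n2nc(SCCCc3ccccc3)nc2n1` differs from compound 1 by phenethyl in place of cyclopropyl on a saturated chain carbon bound to a sulfur. Going by the values given here, the one measured step that bears on this also swapped the cyclopropyl for an aromatic group and raised the number modestly, so a rise of similar size is expected here, giving a 2.0-fold higher number from compound 1 to compound 3 (0.29 log units; within the scatter). Compound 3 is therefore estimated at 55000 nM, within a range of 22000 nM to 130000 nM.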

Compound 3, half-maximal inhibitory concentration: > 100000 nM
Compound 3: no number, only a limit (the forecaster's own chance of this, stated with the estimate: 15%); middle value at least 1.8-fold (0.25 log units) away from the limit.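

In this assay compound 3 gives only a limit of the assay, not a number: the limit of > 100000 nM in this assay, at which 1 of the 3 values shown sits. On a saturated chain carbon bound to a sulfur, phenethyl in place of cyclopropyl gives an at least 3.5-fold higher number from compound 1 to compound 3 (0.55 log units; beyond the scatter), so a second group with an aromatic ring also sits clearly higher than cyclopropyl. Phenethyl in place of 4-methylphenyl gives an at least 1.2-fold higher number from compound 2 to compound 3 (0.08 log units; that floor lies within the scatter), so these two groups cannot be ranked.

On these data alone, the true value of compound 3 stays open. So does how an amine or a carboxylic acid at this place would read.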